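The source may hold more compounds than are shown below. What is called first, only, known or untested is meant among the compounds shown, and "the series" means these compounds.

In an ADME assay on the whole organism (plasma, Homo sapiens) for pharmacokinetics, read by LC-MS, at a dose of 60 mg by the oral route (a lower number here means less compound in the circulation, a higher number more compound in the circulation at the dose given), compound 1 (`CN(C)C(=O)[C@H]1CC[C@H](NC(=O)C(=O)Nc2ccc(Cl)cn2)[C@H](NC(=O)c2nc3c(s2)CNCC3)C1`) gives 13.1 nM and compound 2 (`CN1CCc2nc(C(=O)N[C@@H]3C[C@@H](C(=O)N(C)C)CC[C@@H]3NC(=O)C(=O)O)sc2C1`) gives 34.1 nM, while compound 3 (`CN1CCc2nc(C(=O)N[C@@H]3C[C@@H](C(=O)O)CC[C@@H]3NC(=O)C(=O)Nc3ccc(Cl)cn3)sc2C1`) gives 42.6 nM and so sits within the scatter of compound 2 and beyond the scatter above compound 1. Compound 4 (`CNC(=O)[C@H]1CC[C@H](NC(=O)C(=O)Nc2ccc(Cl)cn2)[C@H](NC(=O)c2nc3c(s2)CN(C)CC3)C1`) differs from compound 3 by methylamino in place of hydroxy on a carbonyl carbon, which turns carboxy into methylcarbamoyl. Within the data shown here, no measured pair isolates this change, so the expectation is loose. Compound 1 also carries an amide on that carbonyl carbon and gives 13.1 nM there, but compound 2, likewise an amide, goes against this with 34.1 nM in the same read-out. In this assay a downward move is expected, estimated as a 2.8-fold lower number from compound 3 to compound 4 (0.45 log units; beyond the scatter) and likely beyond the scatter. For compound 4 the estimated value is 15 nM (expected range 6 nM to 40 nM).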

Compound 4, maximal plasma concentration: 1.18 nM
Compound 4: the middle estimate sits 13-fold (1.10 log units) above what was measured, and the stated range ends above it.
By their numbers in this assay, from the lowest: compound 4; then compound 1; then compounds 2 and 3 (each within the scatter of the next).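

In this assay, among these compounds, methylamino in place of hydroxy on the carbonyl carbon gives a 36-fold lower number from compound 3 to compound 4 (1.56 log units; beyond the scatter) as the only single-place step. Among the compounds shown here, this shows that a small exchange at this carbonyl carbon, carboxy to methylcarbamoyl, can shift maximal plasma concentration strongly, which the earlier compounds, with no isolated pair, could not show. No measurement shown bears on the reason for this drop.

Still open, on these data alone, is whether unsubstituted carbamoyl or ethylcarbamoyl on this carbonyl carbon would track compound 4 or compound 3. Whether the same step holds on other cores also remains unresolved.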